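The compounds below may be only part of what the source reports. "The series", "measured", "known", "first", "only" and "open" are said of these compounds alone.

Compound 1 `CCc1ccc(-n2nc(-c3ccc(C(F)(F)F)cc3O)nc2-c2ccccc2O)cc1` gives 64.4% in a functional assay on PC-12 cells (Rattus norvegicus) for cytotoxicity, read by MTT assay, with stated times of 2 h and 24 h, tested at 1 uM; a higher number here means a stronger effect of the compound at the concentration tested, a lower number a weaker effect. Compound 2 `CC(C)(C)c1ccc(-n2nc(-c3ccc(C(F)(F)F)cc3O)nc2-c2ccccc2O)cc1` gives 67.3% in this assay, and compound 3 `Oc1cc(C(F)(F)F)ccc1-c1nc(-c2ccccc2O)n(-c2ccc(F)cc2)n1` gives 67.2%. Compound 3 thus stands within the scatter of both of its neighbours: a number 2.8 percentage points higher from compound 1 to compound 3 (within the scatter), and a number 0.1 percentage points lower from compound 2 to compound 3 (within the scatter). The change to compound 4 `Oc1cc(C(F)(F)F)ccc1-c1nc(-c2ccccc2O)n(-c2ccc(Cl)cc2)n1` is chloro in place of fluoro on an aromatic carbon. Both measured exchanges on this aromatic carbon, ethyl or tert-butyl giving way to fluoro, left the read-out essentially where it was, so a further exchange of one halogen for another on the same carbon is expected to move the number no further than the scatter allows, with a number 0.2 percentage points lower from compound 3 to compound 4 (within the scatter) as the expected step. Compound 4 is therefore estimated at 67%, within a range from 57% to 77%.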

Compound 4, a percentage reported as activity, at one concentration (the size of the read-out at that concentration, not a potency): 68%
Compound 4: middle estimate off by 1 percentage points, on the low side; the range from low to high includes it.
By their numbers in this assay, from the lowest: compounds 1, 3, 2 and 4 (each within the scatter of the next).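

In this assay, chloro on this aromatic carbon gives a number 0.8 percentage points higher from compound 3 to compound 4 (within the scatter) and a number 0.7 percentage points higher from compound 2 to compound 4 (within the scatter) and also a number 3.6 percentage points higher from compound 1 to compound 4 (within the scatter) in the comparison with the earlier groups. A second halogen therefore cannot be told apart from fluoro, tert-butyl or ethyl here, and across these four groups, para to a large group, the read-out shows no dependence on the group present. Nothing available explains this flat result. The compounds shown leave open whether an amine, a carboxylic acid or a longer chain on this carbon would move the read-out beyond the scatter.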